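Swapping the nitrogen aryl group on compound 2

A few compounds are considered here, and "the series" means these few. Any claim that something is new, unique, unknown or untested is made for them only; others in the source may bear on it.

compound 1 `Cc1cc2occ(-c3nc(-c4ccccc4)c(-c4ccccc4)n3-c3ccc([N+](=O)[O-])cc3)c(=O)c2cc1Cl`: 3130 nM
compound 2 `COc1ccccc1-n1c(-c2coc3cc(C)c(Cl)cc3c2=O)nc(-c2ccccc2)c1-c1ccccc1`: 12500 nM

In a functional assay on A549 cells (Homo sapiens) for inhibition, read by MTT assay, with a stated time of 72 h (on this read-out lower numbers stand for stronger inhibition and higher numbers for weaker inhibition), compound 2 has the higher of the two numbers, at 12500 nM, while compound 1 gives 3130 nM. The next compound, compound 3 `Cc1cc2occ(-c3nc(-c4ccccc4)c(-c4ccccc4)n3-c3ccc(Cl)c(Cl)c3)c(=O)c2cc1Cl`, differs from compound 2 by one change, 3,4-dichlorophenyl in place of 2-methoxyphenyl on an aromatic nitrogen. For the measured compounds named here, only one measured step bears on this place, a 4.0-fold higher number from compound 1 to compound 2 (0.60 log units; beyond the scatter), which is modest and beyond the scatter. With compound 2 at the top of just two numbers, a modest move to a lower number is expected in this assay, although neither measured compound carries the entering group. The expected change is a 2.3-fold lower number from compound 2 to compound 3 (0.36 log units; beyond the scatter). For compound 3 the estimated value is 5500 nM, with an expected range from 1800 nM to 16000 nM.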

Compound 3, half-maximal inhibitory concentration: 6250 nM
Estimate against measurement, compound 3: 1.1-fold (0.06 log units) below; the range from low to high includes it.
By their numbers in this assay, from the lowest: compounds 1, 3 and 2 (each within the scatter of the next, the first and the last beyond it).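

In this assay, the 3,4-dichlorophenyl group on the aromatic nitrogen gives a number that cannot be separated from either earlier group: a 2.0-fold lower number from compound 2 to compound 3 (0.30 log units; within the scatter), and a 2.0-fold higher number from compound 1 to compound 3 (0.30 log units; within the scatter). The two earlier compounds showed only that this place responds to the choice of aryl group, whereas compound 3 now falls within the scatter of both, so the three groups do not form three separate levels, and only the two ends of the set lie beyond the scatter of each other. No evidence available here accounts for these numbers.

As far as these compounds go, it remains open whether a phenyl group carrying an amine or a carboxylic acid at this place would fall outside the span of these three compounds. From the compounds shown here alone, how the numbers respond to changes elsewhere on the shared core also remains open.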